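Carbamate Chain Variation in a Cytotoxicity Series

A few compounds are considered here, and "the series" means these few. Any claim that something is new, unique, unknown or untested is made for them only; others in the source may bear on it.

Compound 1, `CCc1cc(S(=O)(=O)N2C[C@H](c3ccccc3)NC2=O)ccc1NC(=O)OC(C)C`, gives 60 nM in a functional assay on HCT-116 cells (Homo sapiens) for cytotoxicity, read by MTT assay; on this read-out lower numbers stand for stronger inhibition and higher numbers for weaker inhibition.
Compound 2, `Cc1cc(S(=O)(=O)N2C(=O)N[C@@H](c3ccccc3)C2C)ccc1NC(=O)c1ccc(N)cc1`, reaches only the limit of > 10000 nM in this assay.
Compound 3, `CCc1cc(S(=O)(=O)N2C[C@H](c3ccccc3)NC2=O)ccc1NC(=O)NC1CCCCC1`, gives 300 nM in this assay.

Among the two numbers measured, compound 1 stands at the lowest. Its nearest neighbour is compound 3, and the step of a 5.0-fold higher number from compound 1 to compound 3 (0.70 log units; beyond the scatter) separates them, with cyclohexylamino replacing isopropoxy on the carbonyl carbon. Compound 2 sits at the limit of > 10000 nM in this assay, at which 1 of the 3 values shown sits, so its result is a limit and not a number.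

Compound 4, `CCc1cc(S(=O)(=O)N2C[C@H](c3ccccc3)NC2=O)ccc1NC(=O)OCC(C)C`, differs from compound 1 by isobutyl in place of isopropyl on an oxygen next to a carbonyl group. Going by the values given here, only one measured step touches this carbamate carbonyl, the step of a 5.0-fold higher number from compound 1 to compound 3 (0.70 log units; beyond the scatter), and that exchange replaces the whole isopropoxy by a cyclohexylamino. Among the compounds with values here, no measured pair exchanges one alkyl group for another on the carbamate oxygen, so no step bears directly on the change from isopropyl to isobutyl. With one carbon more and the carbamate kept, the step is expected to stay within the scatter of this assay, in either direction.

Compound 4 is therefore estimated at 80 nM, within a range from 30 nM to 250 nM. The expected step of a 1.3-fold higher number from compound 1 to compound 4 (0.12 log units; within the scatter) is small.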

Compound 4, half-maximal inhibitory concentration: 60 nM
Beside the measured number, compound 4's estimate is 1.3-fold (0.12 log units) above it, within the range that was stated.
By their numbers in this assay, from the lowest: compounds 1 and 4 (each within the scatter of the next); then compound 3. At a limit, above all of these: compound 2.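

Going by these compounds alone, on the carbamate oxygen, the one exchange of an alkyl group for another leaves the number in this assay unmoved: isobutyl in place of isopropyl gives no change at the digits printed from compound 1 to compound 4 (within the scatter), so this position accepts both of these small branched chains without a change that can be read. The result also shows that the earlier gap to cyclohexylamino does not rest on isopropoxy alone, since the exchange with isobutoxy gives a 5.0-fold lower number from compound 3 to compound 4 (0.70 log units; beyond the scatter), equal in size to the step seen with isopropoxy, and both carbamates shown stand apart from compound 3 by the same margin. Nothing shown here gives a reason for either step.

How far this tolerance extends remains open, since a longer chain such as n-hexyl, or a benzyl or cyclopentyl group on the oxygen, lies outside the compounds shown. On these data alone, it is also open whether the weaker number of compound 3 goes with the amino nitrogen or with the cyclohexyl ring, which a smaller group such as methylamino or a cyclohexyloxy group on the same carbonyl carbon would separate.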